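From Benzothiazole to Quinazoline: A Stability Step

The source may hold more compounds than are shown below. What is called first, only, known or untested is meant among the compounds shown, and "the series" means these compounds.

Compound 2 `Cc1cc(F)cnc1N1CCN(C(=O)CCCc2cccc3ncsc23)[C@@H](C)C1` is one of three compounds examined in an ADME assay on microsomes from liver (Rattus norvegicus) for metabolic stability, read by LC-MS, with a stated time of 15 min, tested at 1 uM; a higher number here means that more of the compound is left, a lower number that less of the compound is left. Compound 2 gives 5.3%, the lowest of the two numbers reported; compound 3 `N#Cc1ccc(N2CCN(C(=O)CCS(=O)(=O)c3cccc4ncsc34)CC2)nc1` gives 59%, a gap beyond the usual scatter, and for compound 1 `O=C(CCS(=O)(=O)c1cccc2ncsc12)N1CCN(c2ccnc(C(F)(F)F)c2)CC1` this assay reports "not determined" (no result reported). Compound 4 `Cc1cc(F)cnc1N1CCN(C(=O)CCCc2cccc3ncncc23)[C@@H](C)C1` differs from compound 2 in one place: quinazolin-5-yl in place of 1,3-benzothiazol-7-yl on a saturated chain carbon, three bonds along the chain from a carbonyl carbon. Among the measured compounds shown here, no measured pair shows how this exchange shifts the result, so the expectation for compound 4 rests on compound 2 alone. The step of a number 8.7 percentage points higher from compound 2 to compound 4 (within the scatter) is expected to be small and upward, within or only just beyond the scatter. Compound 4 is therefore estimated at 14%, with a range from 3% to 40%.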

Compound 4, percent of the compound remaining: 0%
Estimate against measurement, compound 4: 14 percentage points above; the whole stated range lies above it.
By their numbers in this assay, from the lowest: compounds 4 and 2 (each within the scatter of the next); then compound 3.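

In this assay, among the compounds shown here, putting quinazolin-5-yl in place of 1,3-benzothiazol-7-yl gives the first readable step at this place on the chain, a number 5.3 percentage points lower from compound 2 to compound 4 (within the scatter). Exchanging one of these two ring pairs for the other therefore leaves the result within the scatter, with little of either compound remaining. Nothing measured here bears on the reason for this result. Still open, going by these compounds, is whether a carboxylic acid at this place would leave more compound remaining. A longer chain carrying quinazolin-5-yl also remains an open case.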